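Moving the Nitro Group Along the Benzyl Ether Ring

The source may hold more compounds than are shown below. What is called first, only, known or untested is meant among the compounds shown, and "the series" means these compounds.

Of the compounds shown here, three sharing one core have been measured in a functional assay on Vas deferens for antagonist activity at Alpha-1A adrenergic receptor (Rattus norvegicus); a higher number here means a more potent compound, by a factor of ten per unit of this negative logarithm, a lower number a less potent compound. Compound 1 `COc1cccc(OC)c1OCCNCCOc1ccccc1OCc1cccc(Cl)c1` gives 8.12, compound 2 `COc1cccc(OC)c1OCCNCCOc1ccccc1OCc1ccccc1C` gives 7.81, and compound 3 `COc1cccc(OC)c1OCCNCCOc1ccccc1OCc1ccccc1[N+](=O)[O-]` gives 8.2, the highest of the three, though its gap to compound 1 lies within the scatter. Compound 4 `COc1cccc(OC)c1OCCNCCOc1ccccc1OCc1cccc([N+](=O)[O-])c1` is not yet measured; it differs from compound 3 by 3-nitrophenyl in place of 2-nitrophenyl on a saturated chain carbon bound to an oxygen on an aromatic ring. Among the compounds with values here, two measured steps bear on this: a number 0.39 log units higher from compound 2 to compound 3 (beyond the scatter) and a number 0.08 log units higher from compound 1 to compound 3 (within the scatter). Neither compares the two nitrophenyl groups directly, and compound 1, which carries 3-chlorophenyl at the same place, sits close to compound 3. The step of a number 0.10 log units lower from compound 3 to compound 4 (within the scatter) is therefore expected to be small and within the scatter. Compound 4 is estimated at 8.1, with a range from 7.7 to 8.5.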

Compound 4, negative logarithm of the antagonist equilibrium constant: 8.85
Estimate against measurement, compound 4: 0.75 log units below; the whole stated range lies below it.
By their numbers in this assay, from the lowest: compound 2; then compounds 1 and 3 (each within the scatter of the next); then compound 4.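

Moving the nitro group, with the same atoms joined differently, from 2-nitrophenyl to 3-nitrophenyl gives a number 0.65 log units higher from compound 3 to compound 4 (beyond the scatter), so where the group sits on this ring matters, not only whether it is present. Nitro in place of chloro on an aromatic carbon gives a number 0.73 log units higher from compound 1 to compound 4 (beyond the scatter), and 3-nitrophenyl in place of 2-methylphenyl gives a number 1.04 log units higher from compound 2 to compound 4 (beyond the scatter), the largest step here. As far as these compounds go, whether an amine or a carboxylic acid in place of the nitro would keep this potency remains open. No measurement shown here accounts for the gain.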